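The source may report more compounds than this note shows. Statements on the series, on what has been measured and on what is new or still open speak of the compounds shown alone.

Working notes on the series. Within the data shown here, compound 1 `O=C1C=C(Nc2ccc(I)cc2)C(=O)c2c1nc1n2[C@H]2OC[C@@H](O)[C@H]2OC1` gives 1400 nM in a functional assay on MGC-803 cells (Homo sapiens) for inhibition, read by sulforhodamine B assay (on this read-out lower numbers stand for stronger inhibition and higher numbers for weaker inhibition), the lowest of the two numbers measured so far. Compound 2 `COc1cccc(NC2=CC(=O)c3c(nc4n3[C@H]3OC[C@@H](O)[C@H]3OC4)C2=O)c1` gives 1790 nM in this assay, within the scatter of compound 1. Compound 3 `O=C1C(NC2CC2)=CC(=O)c2c1nc1n2[C@H]2OC[C@@H](O)[C@H]2OC1` reports only a limit of the assay, > 4000 nM, in this assay. Among the measured compounds shown here, the one measured step, an at least 2.2-fold higher number from compound 2 to compound 3 (0.34 log units; beyond the scatter), concerns the exchange of the aryl group on the amine nitrogen for cyclopropyl and rests on (the limit of > 4000 nM in this assay, at which 1 of the 3 values shown sits).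

Compound 4 `CCc1ccc(NC2=CC(=O)c3nc4n(c3C2=O)[C@H]2OC[C@@H](O)[C@H]2OC4)cc1` differs from compound 1 by ethyl in place of iodo on an aromatic carbon. For the measured compounds named here, no measured step touches this change: the aryl amine is kept, and the two aryl amines measured, compound 1 and compound 2, sit within the scatter of each other, so the step from compound 1 to compound 4 in this assay is expected to stay within the scatter, in no set direction. Compound 4 is therefore estimated at 1800 nM, with a range of 900 nM to 3600 nM, which corresponds to an expected step of a 1.3-fold higher number from compound 1 to compound 4 (0.11 log units; within the scatter).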

Compound 4, half-maximal inhibitory concentration: 1290 nM
The estimate for compound 4 lay 1.4-fold (0.14 log units) above the measured number; the measured number falls inside the stated range.
By their numbers in this assay, from the lowest: compounds 4, 1 and 2 (each within the scatter of the next). At a limit, above all of these: compound 3.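

In this assay the step of a 1.1-fold lower number from compound 1 to compound 4 (0.04 log units; within the scatter) shows that ethyl in place of iodo on this aromatic carbon, with one heavy atom leaving and two entering, does not move the number beyond the scatter. The earlier measured step exchanged the whole group on the amine nitrogen, whereas this one touches only the substituent on the phenyl ring, with the (4-ethylphenyl)amino group otherwise matching the (4-iodophenyl)amino group. Nothing at hand bears on a cause for this step.

On these data alone, two groups set no trend at this place, and a carboxylic acid, an amine or a longer chain there remains open. As far as these compounds go, compound 3 gives > 4000 nM, a limit of the assay, and the full size of the step away from the aryl amine remains open.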